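Amide variation in a cytotoxicity series

The source may hold more compounds than are shown below. What is called first, only, known or untested is meant among the compounds shown, and "the series" means these compounds.

Compound 1 `COc1ccc(CN(C)C(=O)c2ccc(-c3cc(-c4cc(OC)ccc4OC)no3)s2)cc1` and compound 2 `COc1ccc(OC)c(-c2cc(-c3ccc(C(=O)NC4CC4)s3)on2)c1` share one core and differ only at the amide. In a functional assay on A549 cells (Homo sapiens) for cytotoxicity, read by XTT assay, with a stated time of 72 h (a higher number here means a weaker inhibitor, a lower number a stronger inhibitor), compound 1 returns a limit of > 30000 nM. In this assay compound 2 likewise returns a limit of > 30000 nM. The step that the two limits leave unreadable from compound 1 to compound 2 is therefore unreadable, since (the limit of > 30000 nM in this assay, at which 2 of the 2 values shown sit). Compound 2 thus stands at the limit, with no number to place it.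

Compound 3 `COc1ccc(OC)c(-c2cc(-c3ccc(C(=O)N4CCC(C(F)(F)F)CC4)s3)on2)c1` carries the change (4-(trifluoromethyl)piperidin-1-yl in place of cyclopropylamino on a carbonyl carbon). For the measured compounds named here, no measured step bears directly on this exchange; the only measured step, a step that the two limits leave unreadable from compound 1 to compound 2, also alters the amide substituent and is itself unreadable. Both measured values sit at the limit of > 30000 nM in this assay, at which 2 of the 2 values shown sit, so no direction can be drawn from them. The step that the limit leaves unreadable from compound 2 to compound 3 is expected to remain within the scatter, with a limit again the likeliest outcome. Compound 3 is estimated at 35000 nM, with a range from 10000 nM to 120000 nM.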

Compound 3, half-maximal inhibitory concentration: > 30000 nM
Compound 3 ended at the assay's limit; the forecaster's own chance of this, stated with the estimate: 80%; the middle value lies beyond the limit too.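

Compound 3 also returns only a limit in this assay, so the steps among compound 1, compound 2 and compound 3 cannot be read: the limit of > 30000 nM in this assay, at which 3 of the 3 values shown sit.

The compounds shown leave open whether any amide on the shared core gives a measurable value in this assay, and how these amides rank.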